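From compound 3 to a dimethyl imidazole: expected half-life

A few compounds are considered here, and "the series" means these few. Any claim that something is new, unique, unknown or untested is made for them only; others in the source may bear on it.

Measured in an ADME assay on microsomes from liver (Homo sapiens) for metabolic stability; on this read-out lower numbers stand for a shorter-lived compound and higher numbers for a longer-lived compound:
- compound 1 `CC(C)C(Cc1ncc[nH]1)c1ccc(-c2ccc3cccc(F)c3c2)[nH]c1=O`: 0.106 h
- compound 2 `CC(C)C(Nc1nnc[nH]1)c1ccc(-c2ccc3cccc(F)c3c2)[nH]c1=O`: > 3 h
- compound 3 `CC(C)C(c1ccc(-c2ccc3cccc(F)c3c2)[nH]c1=O)N1CCN/C1=N\C#N`: 0.632 h

Compound 2 gives > 3 h, which is a limit of the assay and not a number. Of the two true numbers, the higher belongs to compound 3, at 0.632 h.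

Compound 4 `Cc1nc(C(c2ccc(-c3ccc4cccc(F)c4c3)[nH]c2=O)C(C)C)[nH]c1C` has not yet been measured in this assay. It differs from compound 3 at one place: a group of 7 heavy atoms (5 carbon, 2 nitrogen; one five-membered aromatic ring with 2 hetero atoms) in place of a group of 8 heavy atoms (4 carbon, 4 nitrogen; one five-membered non-aromatic ring with 2 hetero atoms), on a saturated chain carbon bound to an aromatic carbon and a saturated chain carbon.

The closest guide is compound 1, which carries a (1H-imidazol-2-yl)methyl group at that place. The measured step there is a 6.0-fold higher number from compound 1 to compound 3 (0.78 log units; beyond the scatter). The two imidazole groups are not the same, so this guide is a loose one. The other steps, an at least 28-fold higher number from compound 1 to compound 2 (1.45 log units; beyond the scatter) and an at least 4.7-fold lower number from compound 2 to compound 3 (0.67 log units; beyond the scatter), show that changes at this place can move the number a long way. A modest fall is therefore expected. The expected change is a 2.5-fold lower number from compound 3 to compound 4 (0.40 log units; beyond the scatter). The estimated half-life of compound 4 is 0.25 h, with an expected range of 0.08 h to 0.8 h.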

Compound 4, half-life: 0.268 h
Compound 4: middle estimate off by 1.1-fold (0.03 log units), on the low side; measured number inside the range.
By their numbers in this assay, from the lowest: compound 1; then compound 4; then compound 3. At a limit, above all of these: compound 2.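

Measured in this assay the change from (1H-imidazol-2-yl)methyl to 4,5-dimethyl-1H-imidazol-2-yl gives a 2.5-fold higher number from compound 1 to compound 4 (0.40 log units; beyond the scatter) and so shows that the number for an imidazole at this place can move beyond the scatter. The dimethyl imidazole still falls short of the non-aromatic ring group, with a 2.4-fold lower number from compound 3 to compound 4 (0.37 log units; beyond the scatter) as the step between them. The gap to the (4H-1,2,4-triazol-3-yl)amino group is wider, at an at least 11-fold lower number from compound 2 to compound 4 (1.04 log units; beyond the scatter) and this size is only a minimum, since the value of compound 2 is a limit and not a number: the limit of > 3 h in this assay, at which 1 of the 4 values shown sits.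

Going by these compounds, the step from compound 1 changes both the methylene link and the two methyl groups, so the share of each stays open. A plain 1H-imidazol-2-yl at this place would separate them, and a 1,2,4-triazolyl group without the amino link would test what that link contributes.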